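The compounds below may be only part of what the source reports. "The series", "measured", "known", "first", "only" and "open" are said of these compounds alone.

- compound 1 `CC(=O)N[C@@H]1CCCc2c1cncc2N1C(=O)c2ccc(Cl)cc2[C@@H]1C` gives < 3.5 mL/min/kg, a limit
- compound 2 `CC(=O)N[C@@H]1CCCc2c1cncc2N1Cc2cc(Cl)ccc2C1=O` gives < 3.5 mL/min/kg, a limit

In an ADME assay on microsomes from liver (Homo sapiens) for metabolic stability, read by LC-MS, using NADPH, with stated times of 10 min and 30 min (a lower number here means slower removal, a higher number faster removal of the compound), compound 2 stands at < 3.5 mL/min/kg, which is a limit of the assay and not a number. The same limit holds for both compounds: the limit of < 3.5 mL/min/kg in this assay, at which 2 of the 2 values shown sit. Compound 3 `CC[C@H]1c2cc(Cl)ccc2C(=O)N1c1cncc2c1CCC[C@H]2NC(C)=O` carries ethyl in place of hydrogen on a saturated ring carbon. Among the measured compounds shown here, the one measured step that bears on this is a step that the two limits leave unreadable from compound 1 to compound 2, so it offers no size to carry over. No step beyond the scatter is therefore expected, and no direction can be read, giving an expected a number no lower from compound 2 to compound 3 (the limit leaves the size open). For compound 3 the estimate is 3.5 mL/min/kg, with an expected range of 2 mL/min/kg to 8 mL/min/kg.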

Compound 3, clearance: < 3.5 mL/min/kg
Compound 3: only a limit was reported (the forecaster's own chance of this, stated with the estimate: 65%); the middle value sits exactly at the limit.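

No step among compound 1, compound 2 and compound 3 can be read, since each result is a limit of the assay and not a number: the limit of < 3.5 mL/min/kg in this assay, at which 3 of the 3 values shown sit.

Going by these compounds, the actual clearance of each compound remains open, as does any effect of methyl or ethyl on the saturated ring carbon.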